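The compounds below may be only part of what the source reports. "The series", "measured", "known", "first", "only" and "open" are said of these compounds alone.

Compound 1 `O=c1oc2ccccc2c2nc3c(ccc4cc[nH]c43)c(-c3ccc(C(F)(F)F)cc3)c12`: 70700 nM
Compound 2 `O=c1oc2ccccc2c2nc3c(ccc4cc[nH]c43)c(-c3ccc(Br)cc3)c12`: 70700 nM
Compound 3 `O=c1oc2ccccc2c2nc3c(ccc4cc[nH]c43)c(-c3c(Cl)cccc3Cl)c12`: 70700 nM

In a functional assay on B16-F10 cells (Mus musculus) for cytotoxicity (a lower number here means a stronger inhibitor, a higher number a weaker inhibitor), compound 3 gives 70700 nM, level with compound 1 and compound 2 at the digits reported. The next change is pyridin-2-yl in place of 2,6-dichlorophenyl on an aromatic carbon, and it leads to compound 4 `O=c1oc2ccccc2c2nc3c(ccc4cc[nH]c43)c(-c3ccccn3)c12`. Three measured steps exchange the aromatic group at this same carbon or its substituent: no change at the digits printed from compound 1 to compound 2 (within the scatter), no change at the digits printed from compound 1 to compound 3 (within the scatter) and no change at the digits printed from compound 2 to compound 3 (within the scatter). Among the compounds with values here, none of them leaves the scatter, although no measured compound carries a pyridin-2-yl group. No step beyond the scatter is therefore expected in this assay, and the estimated step is no change at the digits printed from compound 3 to compound 4 (within the scatter). For compound 4 the estimated value is 70700 nM, with an expected range from 30000 nM to 100000 nM.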

Compound 4, half-maximal inhibitory concentration: 70700 nM
For compound 4 middle estimate and measured number coincide at the digits printed, within the range that was stated.
By their numbers in this assay, from the lowest: compounds 1, 2, 3 and 4 (each within the scatter of the next).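

In this assay the exchange for pyridin-2-yl gives no change at the digits printed from compound 3 to compound 4 (within the scatter) and no change at the digits printed from compound 2 to compound 4 (within the scatter) and also no change at the digits printed from compound 1 to compound 4 (within the scatter). Within the data shown here, the aromatic group at this carbon can therefore carry a ring nitrogen, which none of the earlier compounds has there, without leaving the scatter. Nothing measured here accounts for this sameness. The compounds shown leave open whether an amine or a carboxylic acid on this aromatic group would shift the value, and whether a longer alkyl chain in place of the ring would do so.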